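Changing the Ring on the Side Chain of Compound 2

A few compounds are considered here, and "the series" means these few. Any claim that something is new, unique, unknown or untested is made for them only; others in the source may bear on it.

Compound 1 `OC[C@H]1O[C@@H](n2cnc3c(NCc4ccccc4Cl)ncnc32)[C@H](O)[C@@H]1O` and compound 2 `OC[C@H]1O[C@@H](n2cnc3c(NCc4ccc(F)cc4F)ncnc32)[C@H](O)[C@@H]1O` share one core and differ only in the ring that sits on a saturated chain carbon bound to a nitrogen on an aromatic ring. In a functional assay on HL-60 cells (Homo sapiens) for antiproliferative activity, with a stated time of 72 h (on this read-out higher numbers stand for weaker inhibition and lower numbers for stronger inhibition), compound 1 gives 1600 nM and compound 2 gives 3400 nM. The step of a 2.1-fold higher number from compound 1 to compound 2 (0.33 log units; beyond the scatter) shows that swapping one ring for another at this place moved the number only modestly. Within the data shown here, of the two measured values, compound 2 stands highest, with compound 1 as its only neighbour. Compound 3 `COc1cccc(CNc2ncnc3c2ncn3[C@@H]2O[C@H](CO)[C@@H](O)[C@H]2O)c1O` is not yet measured and differs from compound 2 by 2-hydroxy-3-methoxyphenyl in place of 2,4-difluorophenyl on a saturated chain carbon bound to a nitrogen on an aromatic ring. Among the measured compounds shown here, only the step from compound 1 to compound 2 bears on this change, and it was modest, so no large move beyond the scatter is expected in this assay. The expected step is a 1.4-fold lower number from compound 2 to compound 3 (0.13 log units; within the scatter). Compound 3 is therefore estimated to give 2500 nM, within a range from 800 nM to 8000 nM.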

Compound 3, half-maximal inhibitory concentration: 150 nM
The estimate for compound 3 lay 17-fold (1.22 log units) above the measured number, and the stated range ends above it.
By their numbers in this assay, from the lowest: compound 3; then compound 1; then compound 2.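

In this assay the ring on a saturated chain carbon bound to a nitrogen on an aromatic ring proves able to move the number much further than the earlier swap showed (a 2.1-fold higher number from compound 1 to compound 2 (0.33 log units; beyond the scatter)). Putting in 2-hydroxy-3-methoxyphenyl gives a 23-fold lower number from compound 2 to compound 3 (1.36 log units; beyond the scatter) and, against the 2-chlorophenyl ring, an 11-fold lower number from compound 1 to compound 3 (1.03 log units; beyond the scatter), so a large step is possible at this position when the entering ring carries oxygen, including a hydrogen-bond donor and acceptors, which 2,4-difluorophenyl lacks. Nothing available explains why this change has so large an effect.

Compound 3 brings in its hydroxyl and methoxy groups together, so these compounds cannot show whether one alone accounts for the step. On these data alone, it also remains open how a ring bearing an amine or a carboxylic acid would behave here.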